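A few compounds are considered here, and "the series" means these few. Any claim that something is new, unique, unknown or untested is made for them only; others in the source may bear on it.

Notes on the series. In a functional assay on SW1573 cells (Homo sapiens) for inhibition, read by sulforhodamine B assay, with a stated time of 48 h (on this read-out higher numbers stand for weaker inhibition of growth and lower numbers for stronger inhibition of growth), compound 1 `O=C(/C(=C/C1CCCCC1)CCl)c1ccccc1` gives 23000 nM, compound 2 `O=C(/C(=C/c1ccc(Cl)cc1)CCl)c1ccccc1` gives 3900 nM and compound 3 `CC(=O)OC/C(=C\C1CCCCC1)C(=O)c1ccccc1` gives 19000 nM. Compound 3 thus stands second highest of the three numbers; its nearest neighbour is compound 1, the gap between the two lying within the scatter, while compound 2 shows a lower number that lies beyond the scatter. Among the compounds with values here, the one step measured as a single change is a 1.2-fold lower number from compound 1 to compound 3 (0.08 log units; within the scatter), and it concerns the acetoxy end of the molecule, not the group under consideration here. Compound 4 `CCC(/C=C(\COC(C)=O)C(=O)c1ccccc1)CC` differs from compound 3 in that (pentan-3-yl in place of cyclohexyl on a double-bonded chain carbon bound to a double-bonded chain carbon). Within the data shown here, no measured step tests an exchange of this kind; the single measured step concerns another part of the molecule and was small. The expectation for this assay is therefore a step of a 1.3-fold higher number from compound 3 to compound 4 (0.12 log units; within the scatter) that stays within the scatter, with no direction resolved. Compound 4 is estimated at 25000 nM in this assay, with a range from 8000 nM to 70000 nM.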

Compound 4, concentration for 50% growth inhibition: 77000 nM
Beside the measured number, compound 4's estimate is 3.1-fold (0.49 log units) below it, and the stated range ends below it.
By their numbers in this assay, from the lowest: compound 2; then compounds 3 and 1 (each within the scatter of the next); then compound 4.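

In this assay the exchange of cyclohexyl for pentan-3-yl on a double-bonded chain carbon bound to a double-bonded chain carbon gives a 4.1-fold higher number from compound 3 to compound 4 (0.61 log units; beyond the scatter) and is the first single change shown here to lie beyond the scatter. The earlier step, a 1.2-fold lower number from compound 1 to compound 3 (0.08 log units; within the scatter) and concerning chloro and acetoxy on a saturated chain carbon, stayed within it, so this position is the first shown to respond, with the lower number on the cyclohexyl compound 3. No measurement bearing on the cause of this step is available.

On these data alone, whether a cyclopentyl group or a longer chain such as n-hexyl at this place would stand with compound 3 or with compound 4 remains open. Also open, as far as these compounds go, is whether the same exchange would give a step of this kind with chloro in place of acetoxy on the saturated chain carbon.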